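Anilino variation on the shared core: toward compound 3

The source may report more compounds than this note shows. Statements on the series, on what has been measured and on what is new or still open speak of the compounds shown alone.

Compound 1 `Cc1ccccc1Nc1nc(SCc2ccc(C(F)(F)F)cc2)nc2ccccc12` gives 37500 nM in a functional assay on MCF7 cells (Homo sapiens) for cytotoxicity, read by MTT assay, with a stated time of 72 h; on this read-out higher numbers stand for weaker inhibition and lower numbers for stronger inhibition. Compound 2 `COc1ccc(Nc2nc(SCc3ccc(C(F)(F)F)cc3)nc3ccccc23)c(OC)c1` returns only a limit of the assay in this assay, > 50000 nM. The step of an at least 1.3-fold higher number from compound 1 to compound 2 (0.12 log units; that floor lies within the scatter) is thus known only as a floor, the single case of the limit of > 50000 nM in this assay, at which 1 of the 2 values shown sits. Compound 3 `Fc1ccc(Nc2nc(SCc3ccc(C(F)(F)F)cc3)nc3ccccc23)cc1Cl` differs from compound 2 by 3-chloro-4-fluorophenyl in place of 2,4-dimethoxyphenyl on a nitrogen on an aromatic ring. For the measured compounds named here, no measured step covers this change; the one step on the same nitrogen left both values weak, so nothing points to a gain, and a reading close to the limit is expected. Compound 3 is expected to give 35000 nM, within 10000 nM to 150000 nM, a step of an at least 1.4-fold lower number from compound 2 to compound 3 (0.15 log units; that floor lies within the scatter) that may again end at the limit.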

Compound 3, half-maximal inhibitory concentration: 23000 nM
Compound 3: middle estimate off by 1.5-fold (0.18 log units), on the high side; measured number inside the range.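

For the compounds shown here, on the nitrogen on an aromatic ring, 3-chloro-4-fluorophenyl gives the first step in this assay that clears the scatter: an at least 2.1-fold lower number from compound 2 to compound 3 (0.33 log units; beyond the scatter). Compound 2 stands at a limit of the assay, > 50000 nM, so this step is only a floor: the limit of > 50000 nM in this assay, at which 1 of the 3 values shown sits. Against 2-methylphenyl the same group gives a 1.6-fold lower number from compound 1 to compound 3 (0.21 log units; within the scatter), so the change does not separate compound 1 from compound 3.

From the compounds shown here alone, whether 3-chlorophenyl or 4-fluorophenyl alone would match compound 3 stays open. So does the effect of a phenyl carrying an amine or a carboxylic acid on this nitrogen.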